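Removing the nitro group: expectation for compound 4

This account rests on a few compounds, and the source may have more. Where it says the series, first, only, none or still open, it means among the compounds named here.

The series shares one core, seen in compound 1 `COc1ccc(Nc2nnc(Nc3nc(-c4ccc(Cl)cc4)cs3)s2)cc1`, compound 2 `Cc1ccc(Nc2nnc(Nc3nc(-c4ccc(Br)cc4)cs3)s2)cc1` and compound 3 `Cc1ccc(Nc2nnc(Nc3nc(-c4ccc([N+](=O)[O-])cc4)cs3)s2)cc1`. In a functional assay on the whole organism (strain albino) with Mus musculus as the target, with a stated time of 0.5 h (a higher number here means that more compound is needed for the effect, a lower number that less compound is needed), compound 1 gives 100 mg/kg, compound 2 gives 300 mg/kg and compound 3 gives 300 mg/kg. Compound 3 thus stands level with compound 2, the two together at the highest numbers of the three, while compound 1 sits at a lower number; compound 1 differs from compound 2 in two places, so that gap is not read as a single step. Going by the values given here, the one single-place step measured, no change at the digits printed from compound 2 to compound 3 (within the scatter), shows that exchanging one group on that aromatic carbon leaves the minimum effective dose unchanged.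

Compound 4 `Cc1ccc(Nc2nnc(Nc3nc(-c4ccccc4)cs3)s2)cc1` is obtained from compound 3 by hydrogen in place of nitro on an aromatic carbon, the same difference cut one bond further out reading 4-nitrophenyl to phenyl. Among the compounds with values here, the only step bearing on it, no change at the digits printed from compound 2 to compound 3 (within the scatter), was flat, and no measured pair varies a hydrogen at this carbon. On that basis no change beyond the scatter is expected in this assay, the step of no change at the digits printed from compound 3 to compound 4 (within the scatter) being the estimate. Compound 4 is therefore estimated at 300 mg/kg, with a range from 100 mg/kg to 600 mg/kg.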

Compound 4, minimum effective dose: 300 mg/kg
Compound 4: the middle estimate sits on the measured number at the digits printed; the range from low to high includes it.
By their numbers in this assay, from the lowest: compound 1; then compounds 2, 3 and 4 (each within the scatter of the next).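

In this assay, taking the substituent off altogether gives no change at the digits printed from compound 3 to compound 4 (within the scatter) and hydrogen in place of bromo gives no change at the digits printed from compound 2 to compound 4 (within the scatter) on the same aromatic carbon. Going by these compounds alone, the earlier compounds showed only that one group could be exchanged for another at this carbon, whereas compound 4 adds the unsubstituted phenyl and shows that neither nitro nor bromo is needed for the minimum effective dose to stay at this level. Nitro, bromo and hydrogen thus read alike here with the rest of the structure held constant, although the compounds shown give no measured explanation for this flat result.

Going by these compounds, whether an amine, a carboxylic acid or a longer chain on this carbon would also leave the number in place remains open, as three flat readings at one dose level cover only a narrow set of groups. Compound 1 gives 100 mg/kg but differs from each of the other compounds in two places, so its lower number cannot be assigned to either the chloro or the methoxy group alone.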